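The compounds below may be only part of what the source reports. "The series", "measured", "known", "first", "only" and "open" are said of these compounds alone.

For the measured compounds named here, in a functional assay on the whole organism (stomach) with Rattus norvegicus as the target (on this read-out higher numbers stand for an effect only at larger amounts of compound and lower numbers for an effect already at smaller amounts), compound 1 `N#CNC(=N)NCCCCn1nc(-c2ccccc2)ccc1=O` gives 77.2 mg/kg, the only plain number among the three compounds measured here. Compound 2 `CN/C(=N/CCCCn1nc(-c2ccc(OC)cc2)ccc1=O)NC#N` is recorded only as a limit of the assay, > 100 mg/kg. Compound 3 `C/N=C(/NC#N)NCCCCn1nc(-c2ccc(C)cc2)ccc1=O` likewise gives only a limit, > 100 mg/kg. Compound 1 therefore stands alone with a number; everything else is the limit of > 100 mg/kg in this assay, at which 2 of the 3 values shown sit.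

Compound 4 `N/C(S)=N/CCCCn1nc(-c2ccccc2)ccc1=O` differs from compound 1 in one place: a group of 4 heavy atoms (1 carbon, 2 nitrogen, 1 sulfur; no ring) in place of a group of 6 heavy atoms (2 carbon, 4 nitrogen; no ring), on a saturated chain carbon, four bonds along the chain from an aromatic nitrogen. Going by the values given here, no measured pair differs in just one place, so the size of such a step cannot be read from an example. With compound 1 as the only anchor, the step of a 1.2-fold higher number from compound 1 to compound 4 (0.07 log units; within the scatter) is expected to stay within the scatter, in no clear direction. Compound 4 is thus estimated at 90 mg/kg, within 40 mg/kg to 200 mg/kg.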

Compound 4, dose for half-maximal effect: 36.3 mg/kg
Compound 4: the middle estimate sits 2.5-fold (0.39 log units) above what was measured, outside the stated range (below it).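

For the compounds shown here, the pair of compound 1 and compound 4 gives a comparison at a single place that the earlier compounds could not offer. On a saturated chain carbon, four bonds along the chain from an aromatic nitrogen, the group with the triple bond is not needed for an effect in this assay, since swapping it for the sulfur-bearing group gives a 2.1-fold lower number from compound 1 to compound 4 (0.33 log units; beyond the scatter). This one modest step is all that can be said about the change.

On these data alone, what an amine or a carboxylic acid at this place, or a longer chain, would give stays open. Few plain numbers are available to set against this step: the limit of > 100 mg/kg in this assay, at which 2 of the 4 values shown sit.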